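The source may report more compounds than this note shows. Statements on the series, on what has been measured and on what is new or still open speak of the compounds shown alone.

Measured compounds:
compound 1, `C[C@@H]1NC(=O)C2(Cc3ccccc3C2)NC(=O)[C@H](CCCCCSSc2ccccn2)NC(=O)[C@H]2CCCN2C1=O`, 8.8 nM
compound 2, `C[C@@H]1NC(=O)[C@@]2(CCc3ccccc32)NC(=O)[C@H](CCCCCSSc2ccccn2)NC(=O)[C@H]2CCCN2C1=O`, 12 nM

Both values come from an in vitro assay on 293T cells for inhibition of protein deacetylase HDAC6 (Mus musculus); a higher number here means a weaker inhibitor, a lower number a stronger inhibitor. Compound 2 has the higher of the two numbers, but its nearest neighbour, compound 1, lies within the usual scatter, so the two compounds cannot be told apart on these measurements.

Compound 3, `C[C@@H]1NC(=O)[C@]2(CCc3ccccc32)NC(=O)[C@H](CCCCCSSc2ccccn2)NC(=O)[C@H]2CCCN2C1=O`, has not yet been measured. Compared with compound 2, (the two compounds have the same atoms and bonds and differ only in configuration as drawn: 1 of 4 stereo elements differ; a stereocentre at a saturated ring carbon is drawn S in compound 2 and R in compound 3). Nothing else moves: the two compounds have the same atoms and bonds and differ only in configuration as drawn, at a stereocentre on a saturated ring carbon.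

Going by the values given here, no step between measured compounds shows what a change of configuration at this position does, so the size of the step in this assay is open. Turning a single stereocentre in a rigid cyclic core can leave potency unchanged or shift it considerably in either direction. With compound 2 at 12 nM as the only anchor, compound 3 is expected to give 25 nM in this assay, with a range from 6 nM to 150 nM, so the expected step of a 2.1-fold higher number from compound 2 to compound 3 (0.32 log units; beyond the scatter) is a modest loss with wide uncertainty.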

Compound 3, half-maximal inhibitory concentration: 33 nM
Compound 3: middle estimate off by 1.3-fold (0.12 log units), on the low side; measured number inside the range.
By their numbers in this assay, from the lowest: compounds 1 and 2 (each within the scatter of the next); then compound 3.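

In this assay, turning the stereocentre at this saturated ring carbon from S to R gives a 2.8-fold higher number from compound 2 to compound 3 (0.44 log units; beyond the scatter), so the configuration drawn at this carbon does register in the read-out, though only modestly. The earlier compounds shown here could not show this, as they offered no pair differing in one place and therefore no step of any kind. The step can be tied to this single stereocentre, and to nothing else in the molecule, because of one plain structural fact: the fact that compounds 2 and 3 differ only in the configuration as drawn.

Going by these compounds, whether the S form would keep its edge over the R form with a different group elsewhere on the shared core stays open, for instance with a free thiol in place of the pyridyl disulfide, or with a longer chain carrying that end group. A single pair gives the size of one step at one position, and the reason for that size remains unknown, as does whether a step of this size would recur in a related series.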